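Extending the imine substituent from fluorophenyl to styryl

This account rests on a few compounds, and the source may have more. Where it says the series, first, only, none or still open, it means among the compounds named here.

Measured compounds and their numbers:
compound 1 `COc1ccc(C2C(C#N)=C(/N=C/c3ccc(Cl)cc3)Oc3nc(Nc4ccc(S(N)(=O)=O)cc4)sc32)cc1` gives 9550 nM
compound 2 `COc1ccc(C2C(C#N)=C(/N=C/c3cccc(Br)c3)Oc3nc(Nc4ccc(S(N)(=O)=O)cc4)sc32)cc1` gives 9390 nM
compound 3 `COc1ccc(C2C(C#N)=C(/N=C/c3ccc(F)cc3)Oc3nc(Nc4ccc(S(N)(=O)=O)cc4)sc32)cc1` gives 28900 nM

In a functional assay on MCF7 cells (Homo sapiens) for cytotoxicity, read by sulforhodamine B assay, with a stated time of 48 h (on this read-out higher numbers stand for weaker inhibition and lower numbers for stronger inhibition), compound 3 stands at the highest number of the three. Its distance from compound 1 is a 3.0-fold higher number from compound 1 to compound 3 (0.48 log units; beyond the scatter) and from compound 2 it is a 3.1-fold higher number from compound 2 to compound 3 (0.49 log units; beyond the scatter), while compound 1 and compound 2 lie together, a 1.0-fold lower number from compound 1 to compound 2 (0.01 log units; within the scatter). Compound 4 `COc1ccc(C2C(C#N)=C(/N=C/C=C/c3ccccc3)Oc3nc(Nc4ccc(S(N)(=O)=O)cc4)sc32)cc1` is not yet measured. The change from compound 3 is 2-phenylethenyl in place of 4-fluorophenyl on a carbon with a double bond to nitrogen. Within the data shown here, the steps that bear on this position are the two that exchange the group on the same carbon: replacing a ring-bound halogen moved the number modestly, and the halogenated rings of compounds 1 and 2 did not differ from each other. Among the measured compounds shown here, no measured step introduces a 2-phenylethenyl group, so the direction is uncertain; the earlier steps suggest a modest return towards the numbers of compounds 1 and 2 rather than a large move. Compound 4 is therefore expected at 13000 nM, within 4500 nM to 38000 nM, a step of a 2.2-fold lower number from compound 3 to compound 4 (0.35 log units; beyond the scatter) that is estimated, not measured.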

Compound 4, half-maximal inhibitory concentration: 28900 nM
Estimate against measurement, compound 4: 2.2-fold (0.35 log units) below, and the stated range covers the measured number.
By their numbers in this assay, from the lowest: compounds 2 and 1 (each within the scatter of the next); then compounds 3 and 4 (each within the scatter of the next).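

In this assay, the change to 2-phenylethenyl on a carbon with a double bond to nitrogen gives no change at the digits printed from compound 3 to compound 4 (within the scatter), so a group with a double bond outside the aromatic ring and no halogen cannot be told apart from 4-fluorophenyl. Set against the other two groups, the same change gives a 3.1-fold higher number from compound 2 to compound 4 (0.49 log units; beyond the scatter) and a 3.0-fold higher number from compound 1 to compound 4 (0.48 log units; beyond the scatter), which shows that the higher number at this position is not confined to compound 3 and that only the 3-bromophenyl and 4-chlorophenyl groups of compounds 2 and 1 stand lower. Nothing available explains why these groups separate in this way.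

The compounds shown leave open where a plain phenyl, a 4-nitrophenyl or a 4-dimethylaminophenyl group on this carbon would fall. They also leave open whether a chloro or bromo on the ring of the 2-phenylethenyl group would bring the number back towards compounds 1 and 2.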